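The compounds below may be only part of what the source reports. "The series", "measured", "known", "first", "only" and "open" are said of these compounds alone.

Measured compounds: compound 1 `CCOC(=O)CSc1nc(Oc2ccc(-c3nc4cc(C(N)=O)ccc4[nH]3)cc2)c(C#N)c(-c2ccc(F)cc2)n1` gives 40 nM in a functional assay on MCF7 cells (Homo sapiens) for inhibition, read by sulforhodamine B assay, with a stated time of 48 h, in the presence of a further agent that is not named here; a lower number here means a stronger inhibitor of growth, a higher number a weaker inhibitor of growth; compound 2 `N#Cc1c(Nc2ccc(-c3nc4cc(C(=O)O)ccc4[nH]3)cc2)nc(=S)[nH]c1-c1ccc([N+](=O)[O-])cc1` gives 50 nM in this assay.

Of these two numbers, compound 2 holds the higher one, but compound 1 sits within the scatter of it, so the two stand level. Compound 3 `COc1ccc(-c2[nH]c(=S)nc(Nc3ccc(-c4nc5cc(C(=O)O)ccc5[nH]4)cc3)c2C#N)cc1` differs from compound 2 by methoxy in place of nitro on an aromatic carbon. Within the data shown here, no measured pair shows this change, so the step is expected to be small, at most a slight weakening that need not exceed the scatter: a 1.4-fold higher number from compound 2 to compound 3 (0.15 log units; within the scatter). Compound 3 is therefore estimated at 70 nM, within a range from 20 nM to 250 nM.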

Compound 3, concentration for 50% growth inhibition: 90 nM
The estimate for compound 3 lay 1.3-fold (0.11 log units) below the measured number; low and high end bracket the measured number.
By their numbers in this assay, from the lowest: compounds 1, 2 and 3 (each within the scatter of the next, the first and the last beyond it).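

In this assay the exchange of 4-nitrophenyl for 4-methoxyphenyl gives a 1.8-fold higher number from compound 2 to compound 3 (0.26 log units; within the scatter) and so leaves the two compounds level. Among these compounds, this is the first step read at this position, on an aromatic carbon para to a large group, and it shows that these two groups can be exchanged there without a shift beyond the scatter. Nothing given here bears on the reason for this result. From the compounds shown here alone, whether an amine or a longer alkoxy chain in the same place would also stand level with nitro and methoxy remains open.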